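Fluoro in Place of Chloro, Measured Once and Expected Again

A few compounds are considered here, and "the series" means these few. Any claim that something is new, unique, unknown or untested is made for them only; others in the source may bear on it.

Compound 1, `N#Cc1c(Nc2ccc(Cl)cc2)nc(SCc2cn(Cc3ccccc3Cl)nn2)nc1-c1ccccc1`: 6520 nM
Compound 2, `N#Cc1c(Nc2ccc(F)cc2)nc(SCc2cn(Cc3ccccc3Cl)nn2)nc1-c1ccccc1`: 19900 nM
Compound 3, `Cc1ccc(Nc2nc(SCc3cn(Cc4ccc(Cl)cc4)nn3)nc(-c3ccccc3)c2C#N)cc1`: only a limit, > 64000 nM

In a functional assay on MCF7 cells (Homo sapiens) for inhibition, read by MTT assay, with a stated time of 72 h (a lower number here means a stronger inhibitor, a higher number a weaker inhibitor), compound 1 gives 6520 nM and compound 2 gives 19900 nM. The change between them is fluoro in place of chloro on an aromatic carbon, and it made a 3.1-fold higher number from compound 1 to compound 2 (0.48 log units; beyond the scatter). For compound 3 this assay reports no number but a limit, > 64000 nM, which is the limit of > 64000 nM in this assay, at which 1 of the 3 values shown sits. The difference between the core of compound 1 and the core of compound 3 is not broken down here.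

Compound 4, `Cc1ccc(Nc2nc(SCc3cn(Cc4ccc(F)cc4)nn3)nc(-c3ccccc3)c2C#N)cc1`, is not yet measured. It carries the same change as the measured pair, (fluoro in place of chloro on an aromatic carbon), at the same place. Because compound 3 already sits at the limit of > 64000 nM in this assay, at which 1 of the 3 values shown sits, and the earlier step read a 3.1-fold higher number from compound 1 to compound 2 (0.48 log units; beyond the scatter), compound 4 is expected to remain at or beyond that limit. For compound 4 the expected step is a step that the limit leaves unreadable from compound 3 to compound 4. Compound 4 is estimated at 120000 nM, with a range from 50000 nM to 400000 nM.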

Compound 4, half-maximal inhibitory concentration: 51100 nM
Beside the measured number, compound 4's estimate is 2.3-fold (0.37 log units) above it; the range from low to high includes it.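

In this assay, fluoro in place of chloro gave an at least 1.2-fold lower number from compound 3 to compound 4 (0.09 log units; that floor lies within the scatter), whereas the same change on the other core gave a 3.1-fold higher number from compound 1 to compound 2 (0.48 log units; beyond the scatter), so the step measured on one core did not carry over to the other: the same change on two cores in this assay, a 3.1-fold higher number (0.48 log units; beyond the scatter) from compound 1 to compound 2 and an at least 1.2-fold lower number (0.09 log units; that floor lies within the scatter) from compound 3 to compound 4, at least 3.8-fold (0.58 log units) apart, beyond the scatter of two such steps

Going by these compounds, compound 3 has only a limit, > 64000 nM, so the full size of the second step remains unknown. These two pairs also do not show which difference between the cores goes with the differing steps.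

The compounds shown leave open how bromo or methoxy would read in the same place on either core. They also leave open how the change from chloro to fluoro would behave on further cores.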